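Methoxy for dimethylamino on the pyridine-bearing core

The source may hold more compounds than are shown below. What is called first, only, known or untested is meant among the compounds shown, and "the series" means these compounds.

Measured so far:
Compound 1, `CCCN(CCC)c1cc(C)nc2c(-c3ncccc3C)c(C)nn12`, gives 110 nM in an assay on isolated protein for binding affinity to corticotropin-releasing factor receptor 1 (Homo sapiens); on this read-out lower numbers stand for stronger inhibition and higher numbers for weaker inhibition.
Compound 2, `CCCN(CCC)c1cc(C)nc2c(-c3ncc(C)cc3N(C)C)c(C)nn12`, gives 23 nM in this assay.

Of the two measured compounds, compound 2 has the lower number. Its value in this assay stands apart from that of compound 1 by a gap that exceeds the usual scatter, so compound 2 is the stronger binder of the pair. The two compounds share the same core and differ only in the group carried on the six-membered aromatic ring with one nitrogen.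

Compound 3, `CCCN(CCC)c1cc(C)nc2c(-c3ncc(C)cc3OC)c(C)nn12`, has not yet been measured. It differs from compound 2 in one place: methoxy in place of dimethylamino on an aromatic carbon. The group enters on an aromatic carbon, ortho to a large group, two atoms from the ring nitrogen and meta to a methyl group.

Going by the values given here, no measured step of this kind is available, so the expectation rests on the two values alone. The step from compound 2 to compound 3 is expected to be small, a 1.3-fold higher number from compound 2 to compound 3 (0.12 log units; within the scatter), within or near the scatter. Compound 3 is therefore estimated at 30 nM, with a range from 8 nM to 120 nM.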

Compound 3, inhibition constant: 25 nM
Beside the measured number, compound 3's estimate is 1.2-fold (0.08 log units) above it; low and high end bracket the measured number.
By their numbers in this assay, from the lowest: compounds 2 and 3 (each within the scatter of the next); then compound 1.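

In this assay, going by these compounds alone, putting methoxy in place of dimethylamino on this aromatic carbon, ortho to a large group, gives a 1.1-fold higher number from compound 2 to compound 3 (0.04 log units; within the scatter) and so leaves the read-out unchanged within the scatter, which is the first direct comparison of two groups at this place. The step to the 3-methoxy-5-methylpyridin-2-yl group from the 3-methylpyridin-2-yl group gives a 4.4-fold lower number from compound 1 to compound 3 (0.64 log units; beyond the scatter) and shows that a compound without dimethylamino can also stand clearly apart from compound 1, although this step changes the ring in two places and cannot divide the difference between methoxy and the added methyl group. Nothing available explains why methoxy and dimethylamino read alike here.

The compounds shown leave open how other groups would read on this aromatic carbon, such as a primary amine, a hydroxyl group or a longer chain like ethoxy. They also leave open what methoxy would give without the methyl group on the same ring, and whether the match between methoxy and dimethylamino would hold on a different core.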